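Adding one methoxy to the dimethoxyphenyl compound

A few compounds are considered here, and "the series" means these few. Any claim that something is new, unique, unknown or untested is made for them only; others in the source may bear on it.

- compound 1 `COc1ccc(C2=NOC(COc3ccc(-c4nnnn4-c4cc(OC)c(OC)c(OC)c4)cc3N)C2)cc1N` gives 3000 nM
- compound 2 `COc1ccc(C2=NOC(COc3ccc(-c4nnnn4-c4cc(OC)c(OC)c(OC)c4)cc3N)C2)cc1OC` gives 3570 nM
- compound 3 `COc1cc(C2=NOC(COc3ccc(-c4nnnn4-c4cc(OC)c(OC)c(OC)c4)cc3N)C2)cc(OC)c1OC` has not been measured yet

In a functional assay on MDA-MB-231 cells (Homo sapiens) for cytotoxicity, read by MTT assay, with a stated time of 48 h (a higher number here means a weaker inhibitor, a lower number a stronger inhibitor), compound 2 gives 3570 nM, which lies within the scatter of compound 1, so the two stand level. The move to compound 3 is methoxy in place of hydrogen on an aromatic carbon, which turns 3,4-dimethoxyphenyl into 3,4,5-trimethoxyphenyl. Going by the values given here, only one measured step bears on this. That step, a 1.2-fold higher number from compound 1 to compound 2 (0.08 log units; within the scatter), swapped methoxy in place of amino in the same group and stayed within the scatter. It is a different swap, and one step is thin evidence, so no shift beyond the scatter is expected in this assay, in either direction. The estimate amounts to an expected step of a 1.1-fold lower number from compound 2 to compound 3 (0.05 log units; within the scatter). For compound 3 the expected value is 3200 nM, with an estimated range from 1200 nM to 8000 nM.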

Compound 3, half-maximal inhibitory concentration: 3230 nM
Compound 3: the middle estimate sits 1.0-fold (0.00 log units) below what was measured, and the stated range covers the measured number.
By their numbers in this assay, from the lowest: compounds 1, 3 and 2 (each within the scatter of the next).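

In this assay a methoxy in place of hydrogen on this aromatic carbon gives a 1.1-fold lower number from compound 2 to compound 3 (0.04 log units; within the scatter) and the two compounds stand level, so this position accepts a third methoxy on the ring with no shift beyond the scatter. The wider swap of 3,4,5-trimethoxyphenyl in place of 3-amino-4-methoxyphenyl gives a 1.1-fold higher number from compound 1 to compound 3 (0.03 log units; within the scatter) and likewise leaves the two level, which puts all three ring patterns on the same footing in this test. Nothing available gives a measured reason for this flat result.

Going by these compounds, it remains open whether a group of another kind on this ring, such as a carboxylic acid, a dimethylamino group or a longer chain like butoxy, would move the number beyond the scatter. These three compounds also say nothing about changes elsewhere on the shared core.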